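The source may report more compounds than this note shows. Statements on the series, on what has been measured and on what is new or still open speak of the compounds shown alone.

Compound 1 `CCOC(=O)C1=C(C[Se]C(=O)c2ccc(C)cc2)NC(=O)NC1c1ccc(N(C)C)cc1`: 29600 nM
Compound 2 `CCOC(=O)C1=C(C[Se]C(=O)c2ccc(C)cc2)NC(=O)NC1c1cccc2ccccc12`: 35500 nM
Compound 3 `CCOC(=O)C1=C(C[Se]C(=O)c2ccc(C)cc2)NC(=O)NC1c1ccccc1`: 10500 nM

In a physicochemical assay, read by spectrophotometry, with a stated time of 10 min (a higher number here means that more compound is needed for the effect, a lower number that less compound is needed), compound 3 gives 10500 nM, the lowest of the three numbers, so less of it is needed for the effect than of either of the other two compounds.

The next compound, compound 4 `CCOC(=O)C1=C(C[Se]C(C)=O)NC(=O)NC1c1ccccc1`, keeps the rest of compound 3 but changes one group: methyl in place of 4-methylphenyl on a carbonyl carbon. In words, this is methyl in place of 4-methylphenyl on a carbonyl carbon.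

Going by the values given here, none of the measured compounds differs at that place, since all three carry the same 4-methylphenyl group there. Among the compounds with values here, the only guides are therefore steps made at a different group. These are a 2.8-fold lower number from compound 1 to compound 3 (0.45 log units; beyond the scatter), a 3.4-fold lower number from compound 2 to compound 3 (0.53 log units; beyond the scatter) and a 1.2-fold higher number from compound 1 to compound 2 (0.08 log units; within the scatter). They suggest that a single change in this series may move the number only modestly, but they say nothing about direction for the new change. With no evidence favouring a rise or a fall, no step beyond the scatter is the best expectation, though the uncertainty is wide.

The expected change in this assay is a 1.1-fold higher number from compound 3 to compound 4 (0.06 log units; within the scatter).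

Compound 4 is estimated at 12000 nM, with an expected range from 4000 nM to 35000 nM.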

Compound 4, half-maximal effective concentration: 41200 nM
Compound 4: the middle estimate sits 3.4-fold (0.54 log units) below what was measured; the whole stated range lies below it.
By their numbers in this assay, from the lowest: compound 3; then compounds 1, 2 and 4 (each within the scatter of the next).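

In this assay, going by these compounds alone, the earlier compounds all carried 4-methylphenyl on the carbonyl carbon whose other neighbour is selenium, so they could say nothing about that place, whereas putting methyl there gives a 3.9-fold higher number from compound 3 to compound 4 (0.59 log units; beyond the scatter) and shows that this group counts too. The step is modest, but it is beyond the scatter, so changes at this place, and not only on the saturated ring carbon, can shift how much compound is needed, and here the smaller group without a ring goes with needing more. Nothing measured here gives a reason for this step.

From the compounds shown here alone, with only 4-methylphenyl and methyl seen at this place, it remains open whether the ring or the number of carbons is what tracks the change, and a plain phenyl, a cyclohexyl ring or a longer chain such as butyl on the same carbonyl carbon would help to separate the two. Going by these compounds, it is also open whether methyl would give a similar step with naphthalen-1-yl or 4-(dimethylamino)phenyl on the saturated ring carbon, as in compound 2 and compound 1.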